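The source may hold more compounds than are shown below. What is called first, only, known or untested is meant among the compounds shown, and "the series" means these compounds.

Of the compounds shown here, two built on a shared core have been measured in a functional assay on HT-29 cells (Homo sapiens) for cytotoxicity, read by MTT assay, with a stated time of 72 h; a higher number here means a weaker inhibitor, a lower number a stronger inhibitor. Compound 1 `COc1cc2c(Oc3ccc(NC(=O)c4nnn(-c5ccccc5C(F)(F)F)c4C(F)(F)F)cc3F)ccnc2cc1OCCCN1CCCC1` gives 210 nM in this assay. Compound 2 `COc1cc2c(Oc3ccc(NC(=O)c4nnn(-c5ccc(F)c(F)c5)c4C(F)(F)F)cc3F)ccnc2cc1OCCCN1CCCCC1` gives 180 nM in this assay and stands alongside compound 1, the two numbers lying within the scatter of each other, so neither can be called stronger. Compound 3 `COc1cc2c(Oc3ccc(NC(=O)c4nnn(-c5ccc(F)c(F)c5)c4C(F)(F)F)cc3F)ccnc2cc1OCCCN1CCC(C)CC1` has not yet been measured. It differs from compound 2 in one place: methyl in place of hydrogen on a saturated ring carbon, which reads as piperidin-1-yl becoming 4-methylpiperidin-1-yl. Among the measured compounds shown here, no measured pair shows this change, so its effect is not known from these compounds. With a single methyl entering and nothing leaving but a hydrogen, the step is expected to stay within the scatter, in neither direction. Compound 3 is therefore estimated at 180 nM, with a range from 90 nM to 400 nM. The step this estimate implies, no change at the digits printed from compound 2 to compound 3 (within the scatter), is expected to be small.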

Compound 3, half-maximal inhibitory concentration: 190 nM
For compound 3 the middle estimate is 1.1-fold (0.02 log units) below the measured one; the measured number falls inside the stated range.
By their numbers in this assay, from the lowest: compounds 2, 3 and 1 (each within the scatter of the next).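

In this assay, among the compounds shown here, the swap of piperidin-1-yl for 4-methylpiperidin-1-yl gives a 1.1-fold higher number from compound 2 to compound 3 (0.02 log units; within the scatter), the first step here that isolates a single change. A methyl on this saturated ring carbon, three ring bonds from the ring nitrogen, therefore leaves no readable difference between the two compounds, something the earlier pair could not show because compounds 1 and 2 differ in more than one place. Nothing available explains this result, and the flat step alone cannot say why the number holds.

Going by these compounds, one methyl is a single small probe, so it remains open whether a longer chain such as butyl, a hydroxyl group, an amine or a carboxylic acid at this same carbon would also stay within the scatter. On these data alone, it also remains open whether a methyl on another carbon of this ring would behave the same way.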